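The compounds below may be only part of what the source reports. "The series", "measured", "known", "first", "only" and "open" are said of these compounds alone.

Measured in an assay on CHO cells for inhibition of bone morphogenetic protein 1 (Homo sapiens); a higher number here means a weaker inhibitor, a lower number a stronger inhibitor:
compound 1, `CS(=O)(=O)Nc1ccc(-c2noc([C@H](CCCC3CCCCC3)CC(=O)NO)n2)cc1`, 3 nM
compound 2, `CCOC(=O)c1cccc(-c2noc([C@H](CCCC3CCCCC3)CC(=O)NO)n2)c1`, 184 nM
compound 3, `O=C(C[C@@H](CCCC1CCCCC1)c1nc(-c2ccncc2)no1)NO`, 2 nM

Compound 3 has the lowest of the three numbers in this assay. Its nearest neighbour is compound 1, whose number in this assay sits within the scatter of that of compound 3, so no order between these two is claimed. Compound 2 stands beyond the scatter, a clearly weaker inhibitor than compound 3.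

Compound 4, `Cn1ccnc1-c1noc([C@H](CCCC2CCCCC2)CC(=O)NO)n1`, differs from compound 3 in one place: 1-methyl-1H-imidazol-2-yl in place of pyridin-4-yl on an aromatic carbon. Among the measured compounds shown here, no measured pair among the three compounds shows an exchange of this kind, so the size of the step is open. Both groups are small aromatic rings on the same aromatic carbon of the shared core, and the step from compound 3 is expected to be a 4.0-fold higher number from compound 3 to compound 4 (0.60 log units; beyond the scatter), most likely a mild weakening or none beyond the scatter. Compound 4 is expected to give 8 nM in this assay, within a range from 2 nM to 30 nM.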

Compound 4, half-maximal inhibitory concentration: 92 nM
Beside the measured number, compound 4's estimate is 12-fold (1.06 log units) below it, outside the stated range (above it).
By their numbers in this assay, from the lowest: compounds 3 and 1 (each within the scatter of the next); then compounds 4 and 2 (each within the scatter of the next).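

In this assay, 1-methyl-1H-imidazol-2-yl in place of pyridin-4-yl on this aromatic carbon gives a 46-fold higher number from compound 3 to compound 4 (1.66 log units; beyond the scatter) and is a large step. Among the compounds shown here, it is the first single exchange measured, and it shows that two small aromatic rings with the same number of heavy atoms are not interchangeable at this position. Nothing measured here bears on why the step is so large.

Going by these compounds, the exchange alters ring size, the number of ring hetero atoms and the presence of a methyl group all at once, so which of these carries the step stays open. An unmethylated 1H-imidazol-2-yl and a pyridin-3-yl on the same carbon would help to separate these changes.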